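The source may hold more compounds than are shown below. What is called first, only, known or untested is meant among the compounds shown, and "the series" means these compounds.

Three compounds have so far been measured in a functional assay on MCF7 cells (Homo sapiens) for antiproliferative activity; a higher number here means a weaker inhibitor, a lower number a stronger inhibitor:

compound 1 `Cc1c(O)ccc2cc(-n3cc(-c4ccccc4)nn3)c(=O)oc12` gives 25200 nM
compound 2 `CC(=O)Oc1ccc2cc(-n3cc(-c4ccccc4)nn3)c(=O)oc2c1C` gives 40800 nM
compound 3 `Cc1ccc(-c2cn(-c3cc4ccc(O)c(C)c4oc3=O)nn2)cc1` gives 23200 nM

Compound 3 stands alongside compound 1 and compound 2: its gaps to both lie within the scatter, so the three numbers cannot be told apart. Compound 4 `CC(=O)Oc1ccc2cc(-n3cc(-c4ccc(C)cc4)nn3)c(=O)oc2c1C` has not yet been measured. It differs from compound 3 by acetyl in place of hydrogen on an oxygen on an aromatic ring; cut one bond further out, this reads hydroxy to acetoxy. The same change has been made once already on the shared core: a 1.6-fold higher number from compound 1 to compound 2 (0.21 log units; within the scatter), a step within the scatter. The methyl that sets compound 3 apart from compound 1 gave a 1.1-fold lower number from compound 1 to compound 3 (0.04 log units; within the scatter), again within the scatter. Nothing here points to a shift beyond the scatter in this assay; at most a slight drift to a higher number, as seen from compound 1 to compound 2, is expected. Compound 4 is therefore expected to give about 33000 nM, within a range of 15000 nM to 75000 nM. This expectation amounts to a step of a 1.4-fold higher number from compound 3 to compound 4 (0.15 log units; within the scatter).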

Compound 4, half-maximal inhibitory concentration: > 100000 nM
Compound 4: only a limit was reported (the forecaster's own chance of this, stated with the estimate: 15%); at least 3.0-fold (0.48 log units) between middle value and limit.
By their numbers in this assay, from the lowest: compounds 3, 1 and 2 (each within the scatter of the next). At a limit, above all of these: compound 4.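

In this assay, compound 4 is reported only as a limit, > 100000 nM. The change from hydroxy to acetoxy gives an at least 4.3-fold higher number from compound 3 to compound 4 (0.63 log units; beyond the scatter), so this oxygen on the aromatic ring can matter, which the earlier pair did not show: the same change on two cores in this assay, a 1.6-fold higher number (0.21 log units; within the scatter) from compound 1 to compound 2 and an at least 4.3-fold higher number (0.63 log units; beyond the scatter) from compound 3 to compound 4; the limit leaves it open whether they differ The methyl on the aromatic carbon, whose step stayed within the scatter while the hydroxy was present, gives an at least 2.4-fold higher number from compound 2 to compound 4 (0.38 log units; beyond the scatter) once the acetoxy is there: the same change on two cores in this assay, a 1.1-fold lower number (0.04 log units; within the scatter) from compound 1 to compound 3 and an at least 2.4-fold higher number (0.38 log units; beyond the scatter) from compound 2 to compound 4; the limit leaves it open whether they differ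

On these data alone, the real value of compound 4 remains unknown, and so does whether the acetoxy and methyl changes merely add up or reinforce each other: the limit of > 100000 nM in this assay, at which 1 of the 4 values shown sits. Also open is whether a methyl ether or a longer ester such as propanoyl on that oxygen would behave like the hydroxy or like the acetoxy.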